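The source may hold more compounds than are shown below. What is called first, only, known or untested is meant among the compounds shown, and "the series" means these compounds.

Within the data shown here, in a functional assay on LOX IMVI cells (Homo sapiens) for cytotoxicity, read by MTT assay, with a stated time of 24 h (on this read-out lower numbers stand for stronger inhibition and higher numbers for weaker inhibition), compound 2 `COc1cc(-c2nc(-c3ccccc3)[nH]c2-c2ccnc(NCCCNS(=O)(=O)c3ccc(Br)cc3)n2)ccc1Cl` gives 23700 nM, the lower of the two numbers so far, while compound 1 `COc1cc(-c2nc(-c3ccccc3)[nH]c2-c2ccnc(NCCCNS(=O)(=O)c3ccc(C(F)(F)F)cc3)n2)ccc1F` gives 75200 nM, a gap beyond the scatter. Compound 3 `COc1cc(-c2nc(-c3ccccc3)[nH]c2-c2ccnc(NCCCNS(=O)(=O)c3ccc(C(F)(F)F)cc3)n2)ccc1Cl` is compound 2 with trifluoromethyl in place of bromo on an aromatic carbon, para to a large group: trifluoromethyl in place of bromo on an aromatic carbon. Among the measured compounds shown here, no measured pair shows this change alone. The expectation is therefore a modest rise in the number, meaning somewhat weaker inhibition. The expected change is a 1.6-fold higher number from compound 2 to compound 3 (0.21 log units; within the scatter). For compound 3 the estimated value is 38000 nM, with an expected range of 15000 nM to 90000 nM.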

Compound 3, half-maximal inhibitory concentration: 1780 nM
Beside the measured number, compound 3's estimate is 21-fold (1.33 log units) above it; the measured number lies below the stated range.
By their numbers in this assay, from the lowest: compound 3; then compound 2; then compound 1.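

In this assay, compounds 1 and 2 differed in two places, so their gap could not be assigned to either one. Each change can now be read alone, and both are large: trifluoromethyl in place of bromo, on an aromatic carbon para to a large group, gives a 13-fold lower number from compound 2 to compound 3 (1.12 log units; beyond the scatter), and chloro in place of fluoro on an aromatic carbon gives a 42-fold lower number from compound 1 to compound 3 (1.63 log units; beyond the scatter). Nothing available explains either step. Still open, from the compounds shown here alone, is how an amine or a carboxylic acid would fare at the trifluoromethyl position, and what a longer chain in the linker would do.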